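A few compounds are considered here, and "the series" means these few. Any claim that something is new, unique, unknown or untested is made for them only; others in the source may bear on it.

Compound 1 `O=S(=O)(NCCCNCc1cccc2ccccc12)c1cc(C(F)(F)F)cc(C(F)(F)F)c1` is one of three compounds sharing the same core that have been tested in a functional assay on HPAC cells (Homo sapiens) for inhibition, read by MTT assay, with a stated time of 72 h (on this read-out lower numbers stand for stronger inhibition of growth and higher numbers for weaker inhibition of growth), where compound 1 gives 2400 nM. Compound 2 `COc1ccc(CNCCCNS(=O)(=O)c2cc(C(F)(F)F)cc(C(F)(F)F)c2)cc1OC` gives 3500 nM in this assay, and compound 3 `COc1cccc(CNCCCNS(=O)(=O)c2cc(C(F)(F)F)cc(C(F)(F)F)c2)c1` gives 2400 nM. Compound 1 stands level with compound 3 at the digits reported, and together these two carry the lowest numbers of the three, although every gap in the set lies within the scatter. The step of a 1.5-fold higher number from compound 1 to compound 2 (0.16 log units; within the scatter) and the step of no change at the digits printed from compound 1 to compound 3 (within the scatter) both replace naphthalen-1-yl on a saturated chain carbon bound to an amine nitrogen, and neither moves the read-out beyond the scatter; the step of a 1.5-fold lower number from compound 2 to compound 3 (0.16 log units; within the scatter) likewise stays within it. Compound 4 `O=S(=O)(NCCCNCC1COc2ccccc2O1)c1cc(C(F)(F)F)cc(C(F)(F)F)c1` differs from compound 1 in the following way: 2,3-dihydro-1,4-benzodioxin-2-yl in place of naphthalen-1-yl on a saturated chain carbon bound to an amine nitrogen. The two measured exchanges of naphthalen-1-yl bear directly on this step, and both were small, so that position appears tolerant of exchange across the three compounds shown. It is therefore expected that the step of a 1.3-fold higher number from compound 1 to compound 4 (0.10 log units; within the scatter) will stay within the scatter, with no clear direction. Compound 4 is estimated at 3000 nM, within a range from 1400 nM to 6500 nM.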

Compound 4, concentration for 50% growth inhibition: 2700 nM
Beside the measured number, compound 4's estimate is 1.1-fold (0.05 log units) above it; measured number inside the range.
By their numbers in this assay, from the lowest: compounds 1, 3, 4 and 2 (each within the scatter of the next).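

In this assay, a group with one six-membered non-aromatic ring with 2 hetero atoms and 2 hydrogen-bond acceptors takes the place of naphthalen-1-yl, which has 2 six-membered aromatic rings of carbon only and 0 hydrogen-bond acceptors, and the result is a 1.1-fold higher number from compound 1 to compound 4 (0.05 log units; within the scatter), so this position keeps the read-out within the scatter even when the entering group is not made up of aromatic carbon rings alone. The comparisons with the two methoxy-bearing compounds agree, giving a 1.1-fold higher number from compound 3 to compound 4 (0.05 log units; within the scatter) and a 1.3-fold lower number from compound 2 to compound 4 (0.11 log units; within the scatter), so all four groups on this saturated chain carbon bound to an amine nitrogen now sit within the scatter of one another. Nothing available here bears on why the read-out holds across this exchange.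

Because every group shown still carries at least one six-membered aromatic ring of carbon only, it remains open whether a cyclohexyl group, a carboxylic acid or a further amine on this carbon would also stay within the scatter. Going by these compounds, it is equally open whether a longer chain in the shared core would leave this tolerance of exchange in place.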